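Bromo in Place of Methyl on an Aromatic Carbon

The compounds below may be only part of what the source reports. "The series", "measured", "known", "first", "only" and "open" are said of these compounds alone.

Of the compounds shown here, three that share a common core have been tested in an assay on membranes from brain for displacement of a labelled ligand from Sigma non-opioid intracellular receptor 1 (Cavia porcellus), with a stated time of 90 min; on this read-out lower numbers stand for stronger inhibition and higher numbers for weaker inhibition. Compound 1 `COc1cc2c(cc1OC)CN(CCNC(=O)c1cc(C)ccc1OCCF)CC2` gives 22800 nM in this assay. Compound 2 `COc1cc2c(cc1OC)CN(CCCCNC(=O)c1cc(Br)cc(OC)c1OCCF)CC2` gives 15300 nM in this assay. Compound 3 `COc1cc2c(cc1OC)CN(CCCCNC(=O)c1cc(C)ccc1OCCF)CC2` gives 330 nM in this assay, the lowest of the three numbers; compound 2 is the nearest and compound 1 the furthest, and both gaps lie beyond the scatter. Compound 4 `COc1cc2c(cc1OC)CN(CCCCNC(=O)c1cc(Br)ccc1OCCF)CC2` has not yet been measured. It differs from compound 3 in one place: bromo in place of methyl on an aromatic carbon, in words bromo in place of methyl on an aromatic carbon. Among the measured compounds shown here, no two measured compounds differ in only one place, so no measured step speaks directly to this change. Compound 2 also carries bromo, but it differs from compound 3 in more than one place, so its value shows only what it shows. The step of a 1.5-fold higher number from compound 3 to compound 4 (0.18 log units; within the scatter) is expected to be small, close to the scatter, in either direction. Compound 4 is estimated at 500 nM, with a range from 150 nM to 2500 nM.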

Compound 4, inhibition constant: 1080 nM
Estimate against measurement, compound 4: 2.2-fold (0.33 log units) below, and the stated range covers the measured number.
By their numbers in this assay, from the lowest: compound 3; then compound 4; then compounds 2 and 1 (each within the scatter of the next).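

At this position, para to a 2-fluoroethoxy group, putting bromo in place of methyl gives a 3.3-fold higher number from compound 3 to compound 4 (0.51 log units; beyond the scatter) in this assay and so moves the result beyond the scatter, even though only one heavy atom is exchanged and the count of hydrogen-bond donors and acceptors stays the same. With bromo held in place, hydrogen in place of methoxy on an aromatic carbon gives a 14-fold lower number from compound 2 to compound 4 (1.15 log units; beyond the scatter) as a large step, so the bromo compounds depend strongly on that second ring substituent. The compounds shown hold only methyl and bromo at this position, so it remains open how chloro, nitrile or trifluoromethyl would compare there. On these data alone, it also remains open whether the methyl-to-bromo step would keep its size on the shorter chain of compound 1. Nothing measured here explains why either step occurs.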